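The source may hold more compounds than are shown below. What is called first, only, known or untested is meant among the compounds shown, and "the series" means these compounds.

This account follows the step from compound 2 to compound 3 in a functional assay on HCT-116 cells (Homo sapiens) for inhibition, read by MTT assay, with a stated time of 48 h; on this read-out lower numbers stand for stronger inhibition and higher numbers for weaker inhibition. Compound 1, `COc1cc(NCc2ccc(Cl)cc2)cc(OC)c1OC`, gives > 80000 nM in this assay, which is a limit of the assay rather than a number. Compound 2, `C/C=C/C(=O)N(Cc1ccc(OC)c(N)c1)c1cc(OC)c(OC)c(OC)c1`, gives 300 nM in this assay; it holds the only measured number among the results shown, so it stands alone as the one fixed point. Compound 3, `C/C=C/C(=O)N(Cc1ccc(OC)c(O)c1)c1cc(OC)c(OC)c(OC)c1`, differs from compound 2 by hydroxy in place of amino on an aromatic carbon. Among the measured compounds shown here, no step between two measured compounds has been recorded, so this change has no measured counterpart of its kind. Compound 3 is expected to show an estimated step of a 1.5-fold lower number from compound 2 to compound 3 (0.18 log units; within the scatter) that leans toward stronger inhibition while staying within the usual scatter. Compound 3 is estimated at 200 nM in this assay, with a range from 60 nM to 700 nM.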

Compound 3, half-maximal inhibitory concentration: 55 nM
For compound 3 the middle estimate is 3.6-fold (0.56 log units) above the measured one; measured number below the stated range.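

Until this pair, the 3-amino-4-methoxyphenyl group of compound 2 stood alone, and nothing showed whether this aromatic carbon responds to a change at all. In this assay the move to 3-hydroxy-4-methoxyphenyl gives a 5.5-fold lower number from compound 2 to compound 3 (0.74 log units; beyond the scatter) and so shows that this position, ortho to a methoxy group, is sensitive to the exchange of a single heavy atom, with hydroxy ahead of amino on this read-out. The two groups match in their counts of hydrogen-bond donors and acceptors, neither carries a net charge, and nothing measured here accounts for the step.

The compounds shown leave open how a fluorine atom or a methylamino group on this carbon would compare with hydroxy and amino. Among the compounds shown here, they also leave open whether the same exchange would give a step of like size on another core, as this is the only such pair at hand.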